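The source may hold more compounds than are shown below. What is called first, only, known or untested is meant among the compounds shown, and "the series" means these compounds.

Measured compounds, cytotoxicity on HepG2 cells:

compound 1 `Cc1cc(C)cc(Cc2ccc3c(NCCCNCc4ccco4)ccnc3c2)c1` gives 6270 nM
compound 2 `Fc1ccc(Cc2ccc3c(NCCCNCc4ccco4)ccnc3c2)cc1` gives 5600 nM
compound 3 `COc1ccc(F)cc1CNCCCNc1ccnc2cc(Cc3ccc(F)cc3)ccc12` gives 3530 nM

All three were read in an ADME assay on HepG2 cells (Homo sapiens) for cytotoxicity, read by luminescence, CellTiter-Glo and ATP content, with a stated time of 72 h; a higher number here means that more compound is needed for the effect, a lower number that less compound is needed. Compound 2 and compound 1 share the same core and differ by one change, (3,5-dimethylphenyl in place of 4-fluorophenyl on a saturated chain carbon bound to an aromatic carbon), which made a step of a 1.1-fold higher number from compound 2 to compound 1 (0.05 log units; within the scatter). Compound 3 and compound 2 differ at the other end of the chain, by 5-fluoro-2-methoxyphenyl in place of furan-2-yl on a saturated chain carbon bound to an amine nitrogen, with a step of a 1.6-fold lower number from compound 2 to compound 3 (0.20 log units; within the scatter). Within this set no step between any two measured compounds goes beyond the scatter, so the three values stand together and no compound can be called stronger or weaker than another.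

Compound 4 `COc1ccc(F)cc1CNCCCNc1ccnc2cc(Cc3cc(C)cc(C)c3)ccc12` is not yet measured. It differs from compound 3 by 3,5-dimethylphenyl in place of 4-fluorophenyl on a saturated chain carbon bound to an aromatic carbon. Among the compounds with values here, this is the same change as the one from compound 2 to compound 1, at the same place, so that step is the only direct guide to what compound 4 may do. On this basis the step from compound 3 to compound 4 in this assay is expected to be about a 1.1-fold higher number from compound 3 to compound 4 (0.04 log units; within the scatter), beside the measured 1.1-fold higher number from compound 2 to compound 1 (0.05 log units; within the scatter), because the measured step of a 1.1-fold higher number from compound 2 to compound 1 (0.05 log units; within the scatter) lies within the scatter and gives no reason to expect a movement in either direction. Compound 4 is accordingly estimated at 3900 nM, with a likely range from 1800 nM to 8500 nM.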

Compound 4, half-maximal effective concentration: 940 nM
Estimate against measurement, compound 4: 4.1-fold (0.62 log units) above; the measured number lies below the stated range.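

In this assay, the change from 4-fluorophenyl to 3,5-dimethylphenyl gives a 3.8-fold lower number from compound 3 to compound 4 (0.57 log units; beyond the scatter), so the near-absence of a step on the core of compound 2 does not carry over to the core of compound 3: the same change on two cores in this assay, a 1.1-fold higher number (0.05 log units; within the scatter) from compound 2 to compound 1 and a 3.8-fold lower number (0.57 log units; beyond the scatter) from compound 3 to compound 4, 4.2-fold (0.62 log units) apart, beyond the scatter of two such steps. Read at the other end of the chain, 5-fluoro-2-methoxyphenyl in place of furan-2-yl gives a 6.7-fold lower number from compound 1 to compound 4 (0.82 log units; beyond the scatter), and this step also fails to match its counterpart on the other core: the same change on two cores in this assay, a 1.6-fold lower number (0.20 log units; within the scatter) from compound 2 to compound 3 and a 6.7-fold lower number (0.82 log units; beyond the scatter) from compound 1 to compound 4, 4.2-fold (0.62 log units) apart, beyond the scatter of two such steps. The two lines describe one departure from simple addition within a single square of compounds, all of it resting on compound 4, so they show that a step on one core cannot be assumed on the other here, but they do not show why, nor how general this is in the series.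

Going by these compounds, it remains open whether the lower number of compound 4 belongs only to the pairing of 3,5-dimethylphenyl with 5-fluoro-2-methoxyphenyl, or would also appear with another group at either end, such as a pyridine ring. The compounds shown also leave open whether the same dependence on the core would hold with a longer chain joining the two ends.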